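The source may report more compounds than this note shows. Statements on the series, on what has been measured and on what is new or still open speak of the compounds shown alone.

Measured compounds and their values

Compound 1 `CCOC(=O)CCCCCOc1cccc(CN(C(=O)c2ccc(-c3cccnc3)cc2)C(C)C)c1` in an ADME assay on HepG2 cells (Homo sapiens) for cytotoxicity, read by CellTiter-Glo and resazurin assay, with a stated time of 72 h (on this read-out lower numbers stand for an effect already at smaller amounts and higher numbers for an effect only at larger amounts of compound), gives a limit of the assay, > 26000 nM.
Compound 2 `CCOC(=O)CCCCCOc1cccc(CN(C(=O)c2ccc(-c3cccc(-c4nnc(C)o4)c3)cc2)C(C)C)c1` in this assay gives a limit of the assay, > 26000 nM.
Compound 3 `CCOC(=O)CCCCCOc1cccc(CN(C(=O)c2ccc(-c3ccc4[nH]ccc4c3)cc2)C(C)C)c1` in this assay gives a limit of the assay, > 26000 nM.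

Compound 3 therefore stands only at a limit in this assay, and the two other measured compounds stand at the same limit, (the limit of > 26000 nM in this assay, at which 3 of the 3 values shown sit). None of the steps among these three can be read: the step that the two limits leave unreadable from compound 1 to compound 2, the step that the two limits leave unreadable from compound 1 to compound 3 and the step that the two limits leave unreadable from compound 2 to compound 3 all lie between two limits, so no size and no direction is available from them.

Compound 4 `CCOC(=O)CCCCCOc1cccc(CN(C(=O)c2ccc(-c3cc(OC)cc(OC)c3)cc2)C(C)C)c1` differs from compound 3 in one place: 3,5-dimethoxyphenyl in place of 1H-indol-5-yl on an aromatic carbon. All three measured steps bear on the question only in the sense that every change of this aryl group so far has left the read-out at the limit of this assay, and none of them gives a size to work from. Compound 4 is therefore expected to show no step beyond the scatter, a number no higher from compound 3 to compound 4 (the limit leaves the size open), and most likely to remain at the limit. The estimate for compound 4 in this assay is 26000 nM, between 13000 nM and 52000 nM.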

Compound 4, half-maximal effective concentration: > 26000 nM
Compound 4 ended at the assay's limit; the forecaster's own chance of this, stated with the estimate: 85%; the middle value sits exactly at the limit.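

For the compounds shown here, compound 4 stands only at a limit in this assay, as do compound 1, compound 2 and compound 3, so no step from any of them to compound 4 can be read, in size or in direction: the limit of > 26000 nM in this assay, at which 4 of the 4 values shown sit.

The compounds shown leave open whether these four aryl groups differ at all in this read-out.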